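From a 4-chlorobenzyl to a 3-methylbenzyl group

This account rests on a few compounds, and the source may have more. Where it says the series, first, only, none or still open, it means among the compounds named here.

Compound 2, `COC(=O)[C@H](CCSC)NC(=O)c1ccc(NCc2cncn2Cc2ccc(Cl)cc2)cc1-c1ccccc1`, was tested in a functional assay on NIH3T3 cells (Mus musculus); on this read-out higher numbers stand for an effect only at larger amounts of compound and lower numbers for an effect already at smaller amounts. In this assay compound 2 gives > 10 uM, which is a limit of the assay and not a number. Compound 1, `COC(=O)[C@H](CCSC)NC(=O)c1ccc(CNCc2cncn2Cc2ccc(C#N)cc2)cc1-c1ccccc1C`, gives > 10 uM, again only a limit. Compound 3, `CSCC[C@H](NC(=O)c1ccc(NCc2cncn2Cc2ccc(Cl)cc2)cc1-c1ccccc1)C(=O)O`, gives > 10 uM, also a limit. The single change among these three that can be followed, a step that the two limits leave unreadable from compound 2 to compound 3, is thus unreadable. The whole of the evidence on measured steps is the limit of > 10 uM in this assay, at which 3 of the 3 values shown sit.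

Compound 4, `COC(=O)[C@H](CCSC)NC(=O)c1ccc(NCc2cncn2Cc2cccc(C)c2)cc1-c1ccccc1`, has not yet been measured. It differs from compound 2 by 3-methylphenyl in place of 4-chlorophenyl on a saturated chain carbon bound to an aromatic nitrogen. Among the compounds with values here, no measured step bears on this change; all that the record offers is that every value so far sits at the limit. The step from compound 2 to compound 4 is therefore expected to be a step that the limit leaves unreadable from compound 2 to compound 4, with no direction that the data can point to. Compound 4 is estimated at 20 uM, with a range from 5 uM to 80 uM, and it is expected that the assay will most likely again report only a limit.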

Compound 4, concentration for half-maximal effect: > 10 uM
Compound 4: no number, only a limit (the forecaster's own chance of this, stated with the estimate: 75%); the middle value lies beyond the limit too.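

In this assay compound 4 gives > 10 uM, a limit and not a number. Compound 2 gives > 10 uM, also a limit, and the step between the two cannot be read. The compounds shown leave open which change, if any, would yield a measurable value in this assay.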